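From cyano to 2-acetylethyl on an aromatic carbon

This account rests on a few compounds, and the source may have more. Where it says the series, first, only, none or still open, it means among the compounds named here.

compound 1 `Cc1cc(C#N)cc(C)c1Oc1ccc(N)c(Nc2ccc(C#N)cc2)n1` gives 8980 nM
compound 2 `Cc1cc(/C=C/C(=O)O)cc(C)c1Oc1ccc([N+](=O)[O-])c(Nc2ccc(C#N)cc2)n1` gives 27800 nM
compound 3 `CC(=O)/C=C/c1cc(C)c(Oc2cc(Nc3ccc(C#N)cc3)c([N+](=O)[O-])cc2[N+](=O)[O-])c(C)c1` gives 24400 nM

In an ADME assay on TZM cells (Homo sapiens) for cytotoxicity, read by XTT assay, with a stated time of 4 days (a higher number here means that more compound is tolerated, a lower number that less compound is tolerated), compound 1 holds the lowest of these three numbers (8980 nM), and both other compounds lie above it by more than the usual scatter. Compound 4 `CC(=O)CCc1cc(C)c(Oc2ccc(N)c(Nc3ccc(C#N)cc3)n2)c(C)c1` is still unmeasured. It keeps the core of compound 1, with 2-acetylethyl in place of cyano on an aromatic carbon. Going by the values given here, no measured pair isolates this change, so any forecast is rough. Compound 3 (24400 nM) also carries a chain with a carbonyl, though its core differs, so a modest rise in this assay is expected, possibly not beyond the scatter. The estimated change is a 1.4-fold higher number from compound 1 to compound 4 (0.16 log units; within the scatter) in size. For compound 4 the expected value is 13000 nM (estimated range 5000 nM to 32000 nM).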

Compound 4, half-maximal cytotoxic concentration: 9250 nM
Compound 4: the middle estimate sits 1.4-fold (0.15 log units) above what was measured, and the stated range covers the measured number.
By their numbers in this assay, from the lowest: compounds 1 and 4 (each within the scatter of the next); then compounds 3 and 2 (each within the scatter of the next).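

In this assay, placing 2-acetylethyl instead of cyano on this aromatic carbon gives a 1.0-fold higher number from compound 1 to compound 4 (0.01 log units; within the scatter) and keeps the two compounds within the scatter of each other. Going by these compounds alone, this is the first reading of a single change at this position. The cores of compounds 2 and 3 differ from that of compound 1, so neither gives such a reading. Nothing available here accounts for this result.

From the compounds shown here alone, a sulfonamide or a morpholine at this position remains open. So does whether this swap would read the same on the cores of compounds 2 and 3.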